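Swapping the aryl group on the anilino nitrogen: compound 4

The source may hold more compounds than are shown below. What is called first, only, known or untested is meant among the compounds shown, and "the series" means these compounds.

Compound 1 `COc1ccc(F)cc1Nc1cc(NC(=O)Nc2c(Cl)cccc2Cl)ncn1`: 38.1%
Compound 2 `COc1cc(Br)ccc1Nc1cc(NC(=O)Nc2c(Cl)cccc2Cl)ncn1`: 29.1%
Compound 3 `COc1cc(NC(=O)Nc2cc(Nc3ccc(Br)cc3OC)ncn2)cc(OC)c1`: 36.1%

In a functional assay on NCI-H520 cells (Homo sapiens) for inhibition, read by MTT assay, with a stated time of 48 h, tested at 10 uM (on this read-out lower numbers stand for less inhibition and higher numbers for more inhibition at the one concentration tested (going by the name of the read-out)), compound 2 gives 29.1%, the lowest of the three numbers, though its gaps to compound 1 and compound 3 both lie within the scatter. Compound 4 `CCc1ccc(Nc2cc(NC(=O)Nc3c(Cl)cccc3Cl)ncn2)cc1` has not been measured. It differs from compound 2 by 4-ethylphenyl in place of 4-bromo-2-methoxyphenyl on a nitrogen on an aromatic ring. The step that bears on this change is the earlier aryl swap on the same nitrogen, a number 9 percentage points lower from compound 1 to compound 2 (within the scatter); the other step, a number 7 percentage points higher from compound 2 to compound 3 (within the scatter), sits on the amide-type nitrogen and speaks less directly. Neither moved beyond the scatter, so no step beyond it is expected here either. Compound 4 is therefore estimated at 32%, between 20% and 46%, an expected step of a number 2.9 percentage points higher from compound 2 to compound 4 (within the scatter).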

Compound 4, a percentage reported as inhibition, at one concentration (the size of the read-out at that concentration, not a potency): 31.5%
The estimate for compound 4 lay 0.5 percentage points above the measured number, and the stated range covers the measured number.
By their numbers in this assay, from the lowest: compounds 2, 4, 3 and 1 (each within the scatter of the next).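

In this assay the change to 4-ethylphenyl gives a number 2.4 percentage points higher from compound 2 to compound 4 (within the scatter) and also a number 6.6 percentage points lower from compound 1 to compound 4 (within the scatter) on the same nitrogen. Unlike the earlier aryl swap, this one removes the methoxy group and the halogen together, so at this position neither is required for a number of this size. Nothing measured here accounts for this result. Still open, on these data alone, is whether an amine or a carboxylic acid on this aryl ring, or a longer chain in place of the ethyl group, would move the number beyond the scatter.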